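A Chlorophenyl Ring Replaces Trifluoromethyl on the Sulfonamide Core

This account rests on a few compounds, and the source may have more. Where it says the series, first, only, none or still open, it means among the compounds named here.

Three compounds built on the same sulfonyl-linked pair of piperidine rings have been tested in a functional assay on DLD-1 cells (Homo sapiens) for antiproliferative activity, read by CellTiter-Glo, with a stated time of 72 h; a higher number here means a weaker inhibitor, a lower number a stronger inhibitor. Compound 1 `CC1CCN(C2CCN(S(=O)(=O)c3cccc(C(F)(F)F)c3)CC2)CC1` gives > 5000 nM in this assay, which is a limit of the assay rather than a number. Thus (the limit of > 5000 nM in this assay, at which 1 of the 3 values shown sits). Compound 2 `Cc1cc(C)c(S(=O)(=O)N2CCC(N3CCC(c4ccccc4)CC3)CC2)c(C)c1` gives 865 nM in this assay. Compound 3 `CC1CCN(C2CCN(S(=O)(=O)c3ccc(C#N)cc3)CC2)CC1` gives 2800 nM in this assay. No two of these three differ in only one place, so the numbers stand side by side without any single change being credited for a gap between them.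

Compound 4 `CC1CCN(C2CCN(S(=O)(=O)c3cccc(-c4ccc(Cl)cc4)c3)CC2)CC1` has not yet been measured. It differs from compound 1 in one place: 4-chlorophenyl in place of trifluoromethyl on an aromatic carbon. Among the measured compounds, the one with the largest aromatic group on the sulfonyl, compound 2, gives 865 nM, while compound 3 gives 2800 nM. On that basis compound 4 is expected to move inside the limit that compound 1 met, with the step of an at least 3.3-fold lower number from compound 1 to compound 4 (0.52 log units; beyond the scatter) expected to run toward stronger inhibition. Compound 4 is estimated at 1500 nM in this assay, within a range from 500 nM to 5000 nM.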

Compound 4, half-maximal inhibitory concentration: 15 nM
Compound 4: the middle estimate sits 100-fold (2.00 log units) above what was measured; the measured number lies below the stated range.
By their numbers in this assay, from the lowest: compound 4; then compound 2; then compound 3. At a limit, above all of these: compound 1.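

In this assay, among the compounds shown here, 4-chlorophenyl in place of trifluoromethyl on an aromatic carbon gives an at least 330-fold lower number from compound 1 to compound 4 (2.52 log units; beyond the scatter), the first change whose effect can be read on its own. It shows that this single position, meta to a large group, has a strong influence on the antiproliferative read-out on the shared core, and that a whole extra aromatic ring of carbon only can sit there with a large gain rather than a loss. Compound 1 stands at a limit of the assay, not at a number: the limit of > 5000 nM in this assay, at which 1 of the 4 values shown sits.

The compounds shown cannot tell whether the gain belongs to the added ring, to its chlorine or to the loss of trifluoromethyl, and they give no reason for the size of the step. A plain phenyl, a 4-methoxyphenyl or a pyridine ring on the same carbon would begin to separate these possibilities, and a carboxylic acid or an amine on the added ring would show how much change that ring can take.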